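A few compounds are considered here, and "the series" means these few. Any claim that something is new, unique, unknown or untested is made for them only; others in the source may bear on it.

Measured so far in a functional assay on MCF7 cells (Homo sapiens) for antiproliferative activity, read by MTT assay, with a stated time of 72 h; a higher number here means a weaker inhibitor, a lower number a stronger inhibitor:
compound 1 `CCCCCc1ccc(-c2cn(C[C@H](O)[C@H]3OC(=O)C(OCc4ccccc4)=C3OCc3ccccc3)nn2)cc1` gives 9010 nM.
compound 2 `COc1ccccc1-c1cn(C[C@H](O)[C@H]2OC(=O)C(OCc3ccccc3)=C2OCc2ccccc2)nn1` gives only a limit, > 100000 nM.
compound 3 `O=C1O[C@H]([C@@H](O)Cn2cc(CNS(=O)(=O)c3ccc(F)cc3)nn2)C(OCc2ccccc2)=C1OCc1ccccc1` gives 26800 nM.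

Compound 3 stands highest of the two numbers in this assay; the nearest is compound 1, reached by a 3.0-fold higher number from compound 1 to compound 3 (0.47 log units; beyond the scatter). One value sits at the limit of > 100000 nM in this assay, at which 1 of the 3 values shown sits. Compound 4 `CCCCCCCCCCc1cn(C[C@H](O)[C@H]2OC(=O)C(OCc3ccccc3)=C2OCc2ccccc2)nn1` is not yet measured and differs from compound 3 by nonyl in place of ((4-fluorophenyl)sulfonyl)amino on a saturated chain carbon bound to an aromatic carbon. Among the measured compounds shown here, the steps that bear on this position are a 3.0-fold higher number from compound 1 to compound 3 (0.47 log units; beyond the scatter) and an at least 3.7-fold lower number from compound 2 to compound 3 (0.57 log units; beyond the scatter): both are modest, and the aryl-bearing compound 1 gave the lowest number. Compound 4 carries a plain chain at the same position, so a modest step downward, a 2.7-fold lower number from compound 3 to compound 4 (0.43 log units; beyond the scatter), is expected in this assay. Compound 4 is estimated at 10000 nM, with a range from 3000 nM to 35000 nM.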

Compound 4, half-maximal inhibitory concentration: 80 nM
The estimate for compound 4 lay 130-fold (2.10 log units) above the measured number; measured number outside the range, below it.
By their numbers in this assay, from the lowest: compound 4; then compound 1; then compound 3. At a limit, above all of these: compound 2.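

In this assay a plain decyl chain on the aromatic carbon gives by far the lowest number in the series, with a 340-fold lower number from compound 3 to compound 4 (2.53 log units; beyond the scatter) and a 110-fold lower number from compound 1 to compound 4 (2.05 log units; beyond the scatter). The pentyl chain of compound 1, carried on a phenyl ring, does not reproduce this. Compound 2 is read only as a limit, so its step is a bound, an at least 1200-fold lower number from compound 2 to compound 4 (3.09 log units; beyond the scatter), and the limit is this: the limit of > 100000 nM in this assay, at which 1 of the 4 values shown sits.

Open is how the number depends on chain length, since only decyl is shown: a hexyl or a dodecyl chain would test this. Also open, from the compounds shown here alone, is whether a decyl chain ending in an amine or a carboxylic acid keeps the low number.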